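The compounds below may be only part of what the source reports. "The series", "measured", "known", "first", "only" and "open" are said of these compounds alone.

Compound 1 `CC1CCC(=O)N1CC#CCn1ccnc1` and compound 2 `Cc1cncn1CC#CCN1C(=O)CCC1C` share one core, while compound 3 `CC(=O)N(C)CC#CCn1ccnc1` is built on another; the difference between the two cores is not broken down here. In a functional assay on the whole organism for antagonist activity, with Mus musculus as the target (a lower number here means that less compound is needed, a higher number that more compound is needed for the effect), compound 1 gives 20.9 mg/kg. In this assay compound 2 gives 14.2 mg/kg. The change from compound 1 to compound 2 is methyl in place of hydrogen on an aromatic carbon, and it made a 1.5-fold lower number from compound 1 to compound 2 (0.17 log units; within the scatter). For compound 3 the result in this assay is > 100 mg/kg, which is a limit of the assay rather than a number (the limit of > 100 mg/kg in this assay, at which 1 of the 3 values shown sits). Compound 4 `CC(=O)N(C)CC#CCn1cncc1C` has not yet been measured in this assay. It differs from compound 3 by methyl in place of hydrogen on an aromatic carbon, the same kind of change as that between compound 1 and compound 2, the place being next to the ring atom that bears a group of 9 heavy atoms rather than a large group. The step from compound 3 to compound 4 is expected to be about a step that the limit leaves unreadable from compound 3 to compound 4, resting on the earlier step of a 1.5-fold lower number from compound 1 to compound 2 (0.17 log units; within the scatter). Compound 4 is therefore estimated at 150 mg/kg, most likely again a limit, with a range from 60 mg/kg to 400 mg/kg.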

Compound 4, dose for half-maximal effect: > 100 mg/kg
Compound 4 ended at the assay's limit; the forecaster's own chance of this, stated with the estimate: 75%; the middle value does not contradict the limit.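

In this assay, compound 3 and compound 4 both end at the limit of the assay rather than at a number, so no step between them can be read: the limit of > 100 mg/kg in this assay, at which 2 of the 4 values shown sit.

The compounds shown leave open whether methyl in place of hydrogen on an aromatic carbon changes the result at all on the core of compound 3.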